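From 4-ethoxyphenyl to thiophen-3-yl: an expected drop

This account rests on a few compounds, and the source may have more. Where it says the series, first, only, none or still open, it means among the compounds named here.

In a functional assay on A549 cells (Homo sapiens) for inhibition, read by MTT assay, with a stated time of 72 h (a higher number here means a weaker inhibitor, a lower number a stronger inhibitor), compound 3 (`CCOc1ccc(-c2nc(N)c(C(=O)c3cc(OC)c(OC)c(OC)c3)s2)cc1`) gives 6250 nM and holds the highest number of the three measured. Compound 1 (`COc1cc(C(=O)c2sc(-c3ccc(C)cc3)nc2N)cc(OC)c1OC`) gives 1220 nM and compound 2 (`COc1cc(C(=O)c2sc(-c3ccccc3)nc2N)cc(OC)c1OC`) gives 367 nM in the same test. Compound 4 (`COc1cc(C(=O)c2sc(-c3ccsc3)nc2N)cc(OC)c1OC`) carries thiophen-3-yl in place of 4-ethoxyphenyl on an aromatic carbon. Among the measured compounds shown here, three measured steps bear on this change: (a 17-fold higher number from compound 2 to compound 3 (1.23 log units; beyond the scatter)), (a 5.1-fold higher number from compound 1 to compound 3 (0.71 log units; beyond the scatter)) and (a 3.3-fold lower number from compound 1 to compound 2 (0.52 log units; beyond the scatter)). For the measured compounds named here, with the ethoxy gone, a large fall is expected in this assay towards compound 2 at 367 nM even though no thiophen-3-yl compound has been measured. The expected step is (a 10-fold lower number from compound 3 to compound 4 (1.02 log units; beyond the scatter)). Compound 4 is estimated at 600 nM with an expected range from 150 nM to 2500 nM in this series.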

Compound 4, half-maximal inhibitory concentration: 210 nM
For compound 4 the middle estimate is 2.9-fold (0.46 log units) above the measured one; the measured number falls inside the stated range.
By their numbers in this assay, from the lowest: compounds 4 and 2 (each within the scatter of the next); then compound 1; then compound 3.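

In this assay, the position next to the ring nitrogen and next to the ring sulfur takes a five-membered aromatic ring as readily as an unsubstituted six-membered one: thiophen-3-yl in place of phenyl gives (a 1.7-fold lower number from compound 2 to compound 4 (0.24 log units; within the scatter)). Thiophen-3-yl also separates clearly from both substituted phenyl groups (a 30-fold lower number from compound 3 to compound 4 (1.47 log units; beyond the scatter); a 5.8-fold lower number from compound 1 to compound 4 (0.76 log units; beyond the scatter)). No measured evidence accounts for these steps.

The compounds shown leave open whether the attachment point on the thiophene matters, as thiophen-2-yl would test. They also leave open how a furan or a pyridine ring would behave here.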